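A Methylthiazole Amide in Place of a Methylpyridine Amide

The source may hold more compounds than are shown below. What is called first, only, known or untested is meant among the compounds shown, and "the series" means these compounds.

Compound 1, `O=C(C1CC1)N1CCc2nc(C#Cc3ccccc3)sc2C1`: in an assay on HEK293 cells for positive allosteric modulation of metabotropic glutamate receptor 5 (Homo sapiens), read by FLIPR, with a stated time of 1 h (on this read-out lower numbers stand for an effect already at smaller amounts and higher numbers for an effect only at larger amounts of compound), compound 1 gives > 10000 nM, which is a limit of the assay and not a number.
Compound 2, `Cc1cccc(C(=O)N2CCc3nc(C#Cc4ccccc4)sc3C2)n1`: in this assay compound 2 gives 160 nM.

Compound 2 therefore holds the only true number shown, while compound 1 sits at the limit of > 10000 nM in this assay, at which 1 of the 2 values shown sits. Within the data shown here, the single measured step, an at least 62-fold lower number from compound 1 to compound 2 (1.79 log units; beyond the scatter), shows that the group attached to the carbonyl carbon can change the read-out a great deal. Compound 3, `Cc1nc(C(=O)N2CCc3nc(C#Cc4ccccc4)sc3C2)cs1`, differs from compound 2 by 2-methyl-1,3-thiazol-4-yl in place of 6-methylpyridin-2-yl on a carbonyl carbon. One methyl-bearing aromatic ring is exchanged for another, a far smaller alteration than the one measured, so only a modest shift is expected. For compound 3 the estimate in this assay is 300 nM, with a likely span from 80 nM to 1500 nM. This is expected to amount to a step of a 1.9-fold higher number from compound 2 to compound 3 (0.27 log units; within the scatter), lying near the scatter and, if anything, toward a higher number.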

Compound 3, half-maximal effective concentration: 220 nM
Compound 3: middle estimate off by 1.4-fold (0.13 log units), on the high side; measured number inside the range.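

The exchange gives a 1.4-fold higher number from compound 2 to compound 3 (0.14 log units; within the scatter), so in this assay a six-membered and a five-membered aromatic ring, each carrying a methyl group, cannot be told apart at this place on the carbonyl carbon. Set against the cyclopropyl group, the new ring gives an at least 45-fold lower number from compound 1 to compound 3 (1.65 log units; beyond the scatter), so the large step seen earlier is not tied to 6-methylpyridin-2-yl alone. Compound 1 remains a limit of the assay and not a number: the limit of > 10000 nM in this assay, at which 1 of the 3 values shown sits.

Both rings shown carry a methyl group, so what that methyl group contributes remains open, and a plain phenyl ring would be the direct comparison. From the compounds shown here alone, it is also open whether an aromatic ring is needed at all, since an amine or a longer carbon chain on the carbonyl carbon would test that.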